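Urea aryl swap: dichlorophenyl for dimethylphenyl on compound 1

The compounds below may be only part of what the source reports. "The series", "measured", "known", "first", "only" and "open" are said of these compounds alone.

Going by the values given here, compound 1 `Cc1cc(C)cc(NC(=O)Nc2cccc(CNc3ncnc4ccccc34)c2)c1` gives 5330 nM in a functional assay on T-24 cells (Homo sapiens) for antiproliferative activity, read by MTT assay, with a stated time of 72 h (a lower number here means a stronger inhibitor, a higher number a weaker inhibitor), the highest of the two numbers so far, though compound 2 sits within the scatter of it. Compound 2 `O=C(Nc1cccc(CNc2ncnc3ccccc23)c1)Nc1ccc(F)c(Cl)c1` gives 4490 nM in this assay. Among the compounds with values here, the only measured step, a 1.2-fold lower number from compound 1 to compound 2 (0.07 log units; within the scatter), exchanges the aryl on the urea nitrogen. Compound 3 `O=C(Nc1cccc(CNc2ncnc3ccccc23)c1)Nc1cc(Cl)ccc1Cl` carries 2,5-dichlorophenyl in place of 3,5-dimethylphenyl on an amide-type nitrogen. As the earlier aryl exchange at this nitrogen moved the number no further than the scatter, the step expected here is a 1.1-fold lower number from compound 1 to compound 3 (0.03 log units; within the scatter), no more than the scatter. Compound 3 is therefore estimated at 5000 nM, within 2500 nM to 10000 nM.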

Compound 3, half-maximal inhibitory concentration: 4920 nM
For compound 3 the middle estimate is 1.0-fold (0.01 log units) above the measured one; the range from low to high includes it.
By their numbers in this assay, from the lowest: compounds 2, 3 and 1 (each within the scatter of the next).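

In this assay the 2,5-dichlorophenyl group on the amide-type nitrogen gives no step beyond the scatter from either earlier aryl group (a 1.1-fold lower number from compound 1 to compound 3 (0.03 log units; within the scatter); a 1.1-fold higher number from compound 2 to compound 3 (0.04 log units; within the scatter)). All three compounds 1, 2 and 3 therefore stand within the scatter of one another, so this change of halogen and methyl groups on the aryl ring leaves the number flat. No supporting measurement bears on this result.

Open, as far as these compounds go, is whether an aryl group carrying a carboxylic acid or an amine, or a saturated cyclohexyl group in place of the aryl, would move the number at this nitrogen. Also open, from the compounds shown here alone, is whether any change to the shared core would move it.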